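The source may report more compounds than this note shows. Statements on the series, on what has been measured and on what is new or still open speak of the compounds shown alone.

Compound 1 `CCCCCCCCCCCCCCNC(=O)[C@@H](NC(=O)c1cc2ccccc2n1C)[C@@H](C)O` carries a 1-methyl-1H-indol-2-yl group on a carbonyl carbon. In a functional assay on A-431 cells (Homo sapiens) for cytotoxicity, read by MTT assay, with a stated time of 48 h (a higher number here means a weaker inhibitor, a lower number a stronger inhibitor), compound 1 gives 13700 nM. Compound 2 `CCCCCCCCCCCCCCNC(=O)[C@@H](NC(=O)/C=C/c1ccccc1)[C@@H](C)O` differs from it by 2-phenylethenyl in place of 1-methyl-1H-indol-2-yl on a carbonyl carbon, and in this assay compound 2 gives 64900 nM, so that a 4.7-fold higher number from compound 1 to compound 2 (0.68 log units; beyond the scatter). Compound 3 `CCCCCCCCCCCCCCCCCCNC(=O)[C@@H](NC(=O)c1cc2ccccc2n1C)[C@@H](C)O` keeps the indole group but differs from compound 1 by butyl in place of hydrogen on a saturated chain carbon, ten or more bonds along the chain from an amide-type nitrogen; in this assay compound 3 gives 61000 nM, and a 4.5-fold higher number from compound 1 to compound 3 (0.65 log units; beyond the scatter).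

Compound 4 `CCCCCCCCCCCCCCCCCCNC(=O)[C@@H](NC(=O)/C=C/c1ccccc1)[C@@H](C)O` has not been measured. It differs from compound 3 by 2-phenylethenyl in place of 1-methyl-1H-indol-2-yl on a carbonyl carbon, the same change that separates compound 2 from compound 1, made on the same place. The two cores differ by the longer chain of compound 3, as just described. Since that change produced the step of a 4.7-fold higher number from compound 1 to compound 2 (0.68 log units; beyond the scatter), a similar loss is expected from compound 3, whose own value stands at 61000 nM; the expected step is a 4.4-fold higher number from compound 3 to compound 4 (0.65 log units; beyond the scatter). Compound 4 is estimated at 270000 nM, with a plausible range from 90000 nM to 800000 nM.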

Compound 4, half-maximal inhibitory concentration: 177000 nM
Estimate against measurement, compound 4: 1.5-fold (0.18 log units) above; measured number inside the range.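

In this assay, putting 2-phenylethenyl in place of 1-methyl-1H-indol-2-yl also raises the number on the longer chain (a 2.9-fold higher number from compound 3 to compound 4 (0.46 log units; beyond the scatter)), and this step matches the earlier one within the scatter: the same change on two cores in this assay, a 4.7-fold higher number (0.68 log units; beyond the scatter) from compound 1 to compound 2 and a 2.9-fold higher number (0.46 log units; beyond the scatter) from compound 3 to compound 4, 1.6-fold (0.21 log units) apart, within the scatter of two such steps. Adding butyl to the chain raises the number on the 2-phenylethenyl compounds too (a 2.7-fold higher number from compound 2 to compound 4 (0.44 log units; beyond the scatter)), again matching its earlier step within the scatter: the same change on two cores in this assay, a 4.5-fold higher number (0.65 log units; beyond the scatter) from compound 1 to compound 3 and a 2.7-fold higher number (0.44 log units; beyond the scatter) from compound 2 to compound 4, 1.6-fold (0.21 log units) apart, within the scatter of two such steps. Each change therefore kept its direction and roughly its size when carried to a second core, but this rests on just two cores and a single assay, so it does not show that the same holds for other groups or explain why either change raises the number.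

The compounds shown leave open whether a shorter chain, such as decyl, would continue the trend toward lower numbers. They also leave open whether either step would survive on a core with an amine or a carboxylic acid in place of the 1-methyl-1H-indol-2-yl group.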